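One aromatic ring exchanged on compound 2

A few compounds are considered here, and "the series" means these few. Any claim that something is new, unique, unknown or untested is made for them only; others in the source may bear on it.

Measured in a functional assay on PC-3 cells (Homo sapiens) for antiproliferative activity, read by CCK-8 assay, with a stated time of 6 days (a higher number here means a weaker inhibitor, a lower number a stronger inhibitor), so far:
- Compound 1 `N#Cc1ccc(N2CCc3cc(-c4cncnc4)ccc32)cc1C(F)(F)F` result: "not determined" (no result reported)
- Compound 2 `CCN(c1ccc(C#N)c(Cl)c1)c1cc(-c2ccnn2C)ccc1C` result: 7290 nM

Going by the values given here, compound 2 holds the only number available in this assay and compound 1 offers none to compare it with. Compound 3 `CCN(c1ccc(C#N)c(Cl)c1)c1cc(-c2cccnc2)ccc1C` differs from compound 2 in one place. The exchange pyridin-3-yl in place of 1-methyl-1H-pyrazol-5-yl on an aromatic carbon puts pyridin-3-yl in place of 1-methyl-1H-pyrazol-5-yl on an aromatic carbon, para to a methyl group. Among the compounds with values here, no measured step shows what such an exchange does, so the expectation rests on compound 2 at 7290 nM alone. In this assay no change beyond the scatter is expected, with at most a slight lean towards a stronger inhibitor. The expected 1.3-fold lower number from compound 2 to compound 3 (0.12 log units; within the scatter) is therefore small. For compound 3 the estimated value is 5500 nM with an expected range from 2000 nM to 14000 nM in this measurement.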

Compound 3, half-maximal inhibitory concentration: 11000 nM
For compound 3 the middle estimate is 2.0-fold (0.30 log units) below the measured one; measured number inside the range.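

In this assay, going by these compounds alone, putting pyridin-3-yl in place of 1-methyl-1H-pyrazol-5-yl on this aromatic carbon, para to a methyl group, gives a 1.5-fold higher number from compound 2 to compound 3 (0.18 log units; within the scatter), the first step that can be read at this position. It shows that, in this assay, a six-membered aromatic ring with 1 hetero atom and a five-membered aromatic ring with 2 hetero atoms cannot be told apart at this carbon. No measured evidence here bears on why the two rings read alike.

The compounds shown leave open whether any group at this carbon can move the number beyond the scatter, for instance an amine, a carboxylic acid or a longer chain in place of the ring. On these data alone, whether the same exchange would also read alike on the core of compound 1 stays open too.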